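The source may hold more compounds than are shown below. What is called first, only, known or untested is meant among the compounds shown, and "the series" means these compounds.

Two compounds of this series carry a shared core in which two aromatic rings are joined through a four-carbon dioxy chain, one ring bearing a carboxylic acid and the other a ketone with an adjacent hydroxyl. Compound 1 `Cc1cc(OCCCCOc2ccc(C(=O)CC(C)C)c(O)c2C)ccc1C(=O)O` carries an isobutylcarbonyl ketone, and in an assay on HEK293 cells for positive allosteric modulation of metabotropic glutamate receptor 2 (Rattus norvegicus), read by thallium flux, with a stated time of 2.5 min (on this read-out higher numbers stand for an effect only at larger amounts of compound and lower numbers for an effect already at smaller amounts), compound 1 gives 173 nM. Compound 2 `CC(=O)c1ccc(OCCCCOc2ccc(F)c(C(=O)O)c2)c(C)c1O` carries an acetyl ketone and a fluorine on the acid-bearing ring; in this assay compound 2 gives 259 nM. Compound 2 stands at one end of these two numbers, but its nearest neighbour, compound 1, lies within the usual scatter, so the two values cannot be told apart, and since compound 1 and compound 2 differ in more than one place, their pair says nothing about either change on its own.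

Compound 3 `Cc1c(OCCCCOc2ccc(F)c(C(=O)O)c2)ccc(C(=O)CC(C)C)c1O` is the next step from compound 2: isopropyl in place of hydrogen on a saturated chain carbon bound to a carbonyl carbon. Since compound 1, which already carries the isobutylcarbonyl group, gives 173 nM, no step beyond the scatter is expected in this assay between compound 2 and compound 3, so the step of a 1.4-fold lower number from compound 2 to compound 3 (0.13 log units; within the scatter) is estimated as small. Compound 3 is therefore expected to give about 190 nM, most likely between 80 nM and 450 nM.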

Compound 3, half-maximal effective concentration: 153 nM
Compound 3: the middle estimate sits 1.2-fold (0.09 log units) above what was measured; measured number inside the range.
By their numbers in this assay, from the lowest: compounds 3, 1 and 2 (each within the scatter of the next).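

Compound 3 gives the series its first comparisons in one place. Isopropyl in place of hydrogen on a saturated chain carbon bound to a carbonyl carbon, which also reads as acetyl to isobutylcarbonyl, gives a 1.7-fold lower number from compound 2 to compound 3 (0.23 log units; within the scatter) in this assay, so this change cannot be told from the scatter; the same holds for 3-carboxy-4-fluorophenyl in place of 4-carboxy-3-methylphenyl on an oxygen on a saturated carbon, which gives a 1.1-fold lower number from compound 1 to compound 3 (0.05 log units; within the scatter) and so shows no difference that can be read between these two acid-bearing groups. No independent evidence bears on these results.

The compounds shown leave open whether a longer chain or a cyclohexyl group in place of isopropyl on this carbon would give a step beyond the scatter. They also leave open how an amide in place of the carboxylic acid would read, and what the fluorine and the methyl each contribute on their own, as the second step exchanges the whole carboxyphenyl group at once.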